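The source may hold more compounds than are shown below. What is called first, only, known or untested is meant among the compounds shown, and "the series" means these compounds.

Three compounds share one core and differ only in the group attached to one aromatic carbon. Compound 1 `CN(C)C(=O)c1cc(-c2cnc(NCc3c(F)ccc4c3CCO4)c3cn[nH]c(=O)c23)n(C)n1` gives 2.1 in a physicochemical assay for lipophilicity, using the shake flask method, in phosphate buffer, measured as octanol-water partition, with a stated time of 30 min, at pH 7.4; a lower number here means a more polar compound, a higher number a more lipophilic compound. Compound 2 `Cn1cc(-c2cnc(NCc3c(F)ccc4c3CCO4)c3cn[nH]c(=O)c23)cn1` gives 2.7 in this assay, and compound 3 `CNC(=O)c1cc(-c2cnc(NCc3c(F)ccc4c3CCO4)c3cn[nH]c(=O)c23)n(C)n1` gives 2.1 in this assay. Compound 3 therefore stands level with compound 1, and the two together sit lowest of the three. For the measured compounds named here, the only step away from compound 3 that goes beyond the scatter is a number 0.60 log units lower from compound 2 to compound 3 (beyond the scatter). Exchanging hydrogen in place of methyl on an amide-type nitrogen gave no change at the digits printed from compound 1 to compound 3 (within the scatter).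

Compound 4 `O=C1CCCN1c1cnc(NCc2c(F)ccc3c2CCO3)c2cn[nH]c(=O)c12` has not yet been measured in this assay. It differs from compound 3 in one place: 2-oxopyrrolidin-1-yl in place of 1-methyl-3-(methylcarbamoyl)-1H-pyrazol-5-yl on an aromatic carbon. The measured steps that bear on this are a number 0.60 log units higher from compound 1 to compound 2 (beyond the scatter) and a number 0.60 log units lower from compound 2 to compound 3 (beyond the scatter); both show a lower number with a carbamoyl-bearing pyrazole than with the plain 1-methyl-1H-pyrazol-4-yl. The 2-oxopyrrolidin-1-yl that enters carries no hydrogen-bond donor, yet it is not the plain pyrazole of compound 2 either, so no step beyond the scatter is expected in either direction. For compound 4 the expected value in this assay is 2, within the range 1.5 to 2.6. That expectation amounts to an estimated step of a number 0.10 log units lower from compound 3 to compound 4 (within the scatter).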

Compound 4, distribution coefficient: 1.8
Estimate against measurement, compound 4: 0.20 log units above; the range from low to high includes it.
By their numbers in this assay, from the lowest: compounds 4, 1 and 3 (each within the scatter of the next); then compound 2.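

In this assay, the group on this aromatic carbon need not be a carbamoyl-bearing pyrazole to give a number in this range: with the non-aromatic 2-oxopyrrolidin-1-yl in its place, the result is a number 0.30 log units lower from compound 3 to compound 4 (within the scatter) and a number 0.30 log units lower from compound 1 to compound 4 (within the scatter). This exchange replaces a group with an aromatic ring and a hydrogen-bond donor by a smaller one with neither, yet the number of compound 4 stays within the scatter of the values of both carbamoyl compounds. Against the plain pyrazole, the result is a number 0.90 log units lower from compound 2 to compound 4 (beyond the scatter), so the three compounds whose group at this position contains a carbonyl now sit together, while compound 2, whose group has no carbonyl, stands apart from them.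

No measurement here explains why these three compounds sit together. The compounds shown also leave open whether the carbonyl or the ring of 2-oxopyrrolidin-1-yl matters more, a question that plain pyrrolidin-1-yl could address, and how a morpholine, a primary amine or a carboxylic acid would read at this position.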